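Compound 3 and the loss of its chloro

The compounds below may be only part of what the source reports. "The series", "measured", "known", "first", "only" and "open" are said of these compounds alone.

For the measured compounds named here, in a functional assay on the whole organism (Hindlimb, strain albino) with Mus musculus as the target, in the maximal electroshock model, with a stated time of 0.5 h (a higher number here means that more compound is needed for the effect, a lower number that less compound is needed), compound 3 `CC(=O)N1N=C(Nc2nc3ccc(Cl)cc3s2)CC1c1ccc(O)cc1` gives 106 umol/kg and holds the lowest of the three numbers so far. Compound 2 `COc1ccc(C2CC(Nc3nc4ccccc4s3)=NN2C(C)=O)cc1` reads 226 umol/kg and lies beyond the scatter from compound 3. Compound 1 `CC(=O)N1N=C(Nc2nc3ccccc3s2)CC1OC1=CC=C1` reads 382 umol/kg and also lies beyond the scatter from compound 3. Compound 4 `CC(=O)N1N=C(Nc2nc3ccccc3s2)CC1c1ccc(O)cc1` differs from compound 3 by a single change hydrogen in place of chloro on an aromatic carbon that puts hydrogen in place of chloro on an aromatic carbon. Going by the values given here, the one measured step of a 1.7-fold lower number from compound 1 to compound 2 (0.23 log units; within the scatter) lies within the scatter and sits on a saturated ring carbon, so no measured step covers this change directly. Compound 2 carries no chloro and at 226 umol/kg has a higher number than compound 3, though the two also differ in a second place. On that slender evidence a move to a higher number is expected, with a 1.9-fold higher number from compound 3 to compound 4 (0.28 log units; within the scatter) as the estimated step, about the size of the scatter. In this assay compound 4 is expected at 200 umol/kg with an estimated range from 95 umol/kg to 400 umol/kg as the likely span.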

Compound 4, dose for half-maximal effect: 249 umol/kg
Compound 4: the middle estimate sits 1.2-fold (0.10 log units) below what was measured, and the stated range covers the measured number.
By their numbers in this assay, from the lowest: compound 3; then compounds 2, 4 and 1 (each within the scatter of the next).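

In this assay the exchange of chloro for hydrogen on this aromatic carbon now has a direct reading: a 2.3-fold higher number from compound 3 to compound 4 (0.37 log units; beyond the scatter) lies beyond the scatter, so the chloro of compound 3 goes with the lower number, a modest step measured in one pair only. The other two changes do not separate their compounds: hydrogen in place of methyl on the oxygen gives a 1.1-fold higher number from compound 2 to compound 4 (0.04 log units; within the scatter) and stays within the scatter, and the exchange of the group on the saturated ring carbon gives a 1.5-fold lower number from compound 1 to compound 4 (0.19 log units; within the scatter) and also stays within it. Nothing shown offers a measured account of why the chloro step occurs. From the compounds shown here alone, whether bromo or an amine on this aromatic carbon would match the chloro remains open. So does whether the chloro step would hold with methyl on the oxygen or with the other group on the saturated ring carbon.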